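The compounds below may be only part of what the source reports. "The series", "measured", "known", "first", "only" and "open" are said of these compounds alone.

In a functional assay on A549 cells (Homo sapiens) for cytotoxicity, read by MTT assay, with a stated time of 72 h (on this read-out higher numbers stand for weaker inhibition and lower numbers for stronger inhibition), compound 1 (`CC1CCN(Cc2ccc3nc(NC(=O)N/N=C/c4cn(Cc5ccc(Cl)cc5Cl)c5ccccc45)sc3c2)CC1`) gives 3640 nM, compound 2 (`CCN(CC)Cc1ccc2nc(NC(=O)N/N=C/c3cn(Cc4ccc(Cl)cc4Cl)c4ccccc34)sc2c1`) gives 1900 nM and compound 3 (`CN(C)Cc1ccc2nc(NC(=O)N/N=C/c3cn(Cc4ccccc4)c4ccccc34)sc2c1`) gives 2900 nM, a value within the scatter of the other two. Compound 4 (`CN(C)Cc1ccc2nc(NC(=O)N/N=C/c3cn(Cc4ccc(Cl)cc4Cl)c4ccccc34)sc2c1`) remains to be measured. It departs from compound 3 at one place, with 2,4-dichlorophenyl in place of phenyl on a saturated chain carbon bound to an aromatic nitrogen.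

Going by the values given here, no measured step covers this change. Among the compounds with values here, the only step available, a 1.9-fold lower number from compound 1 to compound 2 (0.28 log units; within the scatter), is diethylamino in place of 4-methylpiperidin-1-yl, at a different place, and it stays within the scatter. The 2,4-dichlorophenyl group is already present in compound 1 at 3640 nM and in compound 2 at 1900 nM, and both values lie within the scatter of compound 3 at 2900 nM. No step beyond the scatter is therefore expected in this assay. The expected step is a 1.3-fold lower number from compound 3 to compound 4 (0.10 log units; within the scatter). The estimate for compound 4 is 2300 nM, in an expected range of 1000 nM to 5000 nM.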

Compound 4, half-maximal inhibitory concentration: 2000 nM
For compound 4 the middle estimate is 1.2-fold (0.06 log units) above the measured one; the range from low to high includes it.
By their numbers in this assay, from the lowest: compounds 2, 4, 3 and 1 (each within the scatter of the next).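

Benzyl to 2,4-dichlorobenzyl can now be read directly at this place, on a saturated chain carbon bound to an aromatic nitrogen, with dimethylamino held constant in this assay (a 1.5-fold lower number from compound 3 to compound 4 (0.16 log units; within the scatter)). The two added chlorine atoms therefore give no separation beyond the scatter in this matched pair. With 2,4-dichlorobenzyl held constant, dimethylamino also stays within the scatter of the other two amines (a 1.1-fold higher number from compound 2 to compound 4 (0.02 log units; within the scatter); a 1.8-fold lower number from compound 1 to compound 4 (0.26 log units; within the scatter)), so all three amine steps in the compounds shown remain small and none goes against this.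

The compounds shown leave open whether morpholin-4-yl or piperazin-1-yl in place of these amines, or 4-methoxybenzyl or a longer alkyl chain in place of 2,4-dichlorobenzyl, would give a step beyond the scatter. No available evidence bears on the reason for these small steps.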